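Thiocarbamate with cyclopentyl in place of a cyclopropyl carbamate

The compounds below may be only part of what the source reports. "The series", "measured", "known", "first", "only" and "open" are said of these compounds alone.

Three compounds have numbers in an assay on DDT1 cells (Cricetulus griseus) for binding affinity to adenosine receptor A1 (Homo sapiens), read by radioligand binding; on this read-out higher numbers stand for weaker inhibition and lower numbers for stronger inhibition:
compound 1 `CCC/N=C(\S)OC[C@H]1OC(n2cnc3c(NC4CCOC4)ncnc32)[C@H](O)[C@@H]1O`, which in this assay gives 50 nM;
compound 2 `CCCCNC(=O)OC[C@H]1OC(n2cnc3c(NC4CCOC4)ncnc32)[C@H](O)[C@@H]1O`, which in this assay gives 1410 nM;
compound 3 `O=C(NC1CC1)OC[C@H]1OC(n2cnc3c(NC4CCOC4)ncnc32)[C@H](O)[C@@H]1O`, which in this assay gives 209 nM.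

Compound 3 stands second highest of the three numbers; its nearest neighbour is compound 1, its furthest compound 2, as the steps of a 4.2-fold higher number from compound 1 to compound 3 (0.62 log units; beyond the scatter) and a 6.7-fold lower number from compound 2 to compound 3 (0.83 log units; beyond the scatter) show.

Compound 4 `O[C@@H]1[C@@H](CO/C(S)=N/C2CCCC2)OC(n2cnc3c(NC4CCOC4)ncnc32)[C@@H]1O` differs from compound 3 by a group of 8 heavy atoms (6 carbon, 1 nitrogen, 1 sulfur; one five-membered non-aromatic ring of carbon only) in place of a group of 6 heavy atoms (4 carbon, 1 nitrogen, 1 oxygen; one three-membered non-aromatic ring of carbon only), on an oxygen on a saturated carbon. For the measured compounds named here, two measured steps bear on this change. The step of a 4.2-fold higher number from compound 1 to compound 3 (0.62 log units; beyond the scatter) shows the sulfur-bearing group in compound 1 giving the lower number than the oxygen-bearing cyclopropyl group; the step of a 28-fold higher number from compound 1 to compound 2 (1.45 log units; beyond the scatter) points the same way, with the butyl carbamate of compound 2 far weaker. Going by the values given here, no measured pair isolates cyclopentyl against cyclopropyl or propyl, so that part of the change has no precedent here. A modest step downward is therefore expected for compound 4, roughly reversing the step from compound 1 to compound 3, with the estimate a 3.5-fold lower number from compound 3 to compound 4 (0.54 log units; beyond the scatter). Compound 4 is estimated at 60 nM, in the range 15 nM to 250 nM.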

Compound 4, inhibition constant: 72 nM
For compound 4 the middle estimate is 1.2-fold (0.08 log units) below the measured one; measured number inside the range.
By their numbers in this assay, from the lowest: compounds 1 and 4 (each within the scatter of the next); then compound 3; then compound 2.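

In this assay, for the compounds shown here, the step of a 1.4-fold higher number from compound 1 to compound 4 (0.16 log units; within the scatter) shows that cyclopentyl can stand in place of propyl on a double-bonded nitrogen with the two numbers within the scatter of each other, a comparison the earlier compounds did not offer. The low number of compound 1 is thus not confined to a propyl chain: the sulfur-bearing group with a cyclopentyl ring also stands apart from both carbamates, through a 2.9-fold lower number from compound 3 to compound 4 (0.46 log units; beyond the scatter) and a 20-fold lower number from compound 2 to compound 4 (1.29 log units; beyond the scatter) in this assay. Each of these two steps changes the ring or chain together with the sulfur-bearing group, so neither isolates one part.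

Open, from the compounds shown here alone, is how a cyclopentyl carbamate would compare, which would separate the share of the ring from that of the sulfur-bearing group. Also open, going by these compounds, is whether phenyl or a longer chain such as hexyl on that nitrogen would hold the number. No measurement given here explains these differences.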